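A Ring Rearrangement at the Carbamate Carbonyl

The compounds below may be only part of what the source reports. "The series", "measured", "known", "first", "only" and "open" are said of these compounds alone.

Measured compounds:
compound 1 `C#CC(=O)N1CCN(C(=O)Oc2cc3c(Nc4ccc(Cl)c(Cl)c4F)ncnc3cc2OC)[C@H](C)C1`: 671 nM
compound 2 `C=CC(=O)N1CCN(C(=O)Oc2cc3c(Nc4cccc(Cl)c4F)ncnc3cc2OC)[C@H](C)C1`: 464 nM

Both numbers come from a functional assay on NCI-H358 cells (Homo sapiens) for antiproliferative activity, read by CCK-8 assay, with a stated time of 72 h; a higher number here means a weaker inhibitor of growth, a lower number a stronger inhibitor of growth. Compound 1 has the highest of the two numbers, but its nearest neighbour, compound 2, sits only a little lower, and that gap lies within the scatter of the method, so the two cannot be ranked against each other.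

Compound 3 `C=CC(=O)N1C[C@@H]2C[C@H]1CN2C(=O)Oc1cc2c(Nc3ccc(Cl)c(Cl)c3F)ncnc2cc1OC` has not yet been measured in this assay. It differs from compound 1 in one place: a group of 11 heavy atoms (8 carbon, 2 nitrogen, 1 oxygen; 2 five-membered non-aromatic rings with 1 hetero atom each) in place of a group of 11 heavy atoms (8 carbon, 2 nitrogen, 1 oxygen; one six-membered non-aromatic ring with 2 hetero atoms), on a carbonyl carbon. The two compounds share every atom; only the way the atoms are joined changes, the single six-membered ring giving way to two five-membered rings, and the triple bond to a second double bond.

Among the measured compounds shown here, no measured pair shows this step, so the expectation rests on the shared core alone. Compound 3 is expected to give 550 nM, with a range from 170 nM to 1800 nM. The step of a 1.2-fold lower number from compound 1 to compound 3 (0.09 log units; within the scatter) is thus expected to stay within the scatter, with no clear direction.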

Compound 3, concentration for 50% growth inhibition: 23.3 nM
Compound 3: middle estimate off by 24-fold (1.37 log units), on the high side; the measured number lies below the stated range.
By their numbers in this assay, from the lowest: compound 3; then compounds 2 and 1 (each within the scatter of the next).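

In this assay the group on this carbonyl carbon turns out to matter greatly, with a 29-fold lower number from compound 1 to compound 3 (1.46 log units; beyond the scatter) as the result of rejoining the same atoms. Compounds 1 and 2 could not show this: they differ in more than one place and lie within the scatter of each other. Neither the heavy-atom count nor the hydrogen-bond counts of the group change, and no measurement shown explains the step.

The change is really two edits made together, the two five-membered rings replacing the six-membered ring and a double bond replacing the triple bond, and the compounds shown cannot separate them. An ethynylcarbonyl group on the new ring pair, or a propenoyl group on the 2-methylpiperazine ring with the core of compound 1, would tell the two apart.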